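From 4-hydroxyphenyl to 3-chlorophenyl at the chain's end

The source may report more compounds than this note shows. Statements on the series, on what has been measured and on what is new or still open speak of the compounds shown alone.

Compound 1 (`Cc1ccc2[nH]c(-c3ccc(-c4ccc(-c5cccc(Cl)c5)cc4)cc3)nc2c1`): 2800 nM
Compound 2 (`Oc1ccc(-c2ccc(-c3ccc(-c4nc5ccccc5[nH]4)cc3)cc2)cc1`): 33100 nM

In a functional assay on A549 cells (Homo sapiens) for inhibition, read by sulforhodamine B assay (a higher number here means a weaker inhibitor of growth, a lower number a stronger inhibitor of growth), compound 2 stands highest of the two measured compounds at 33100 nM, and the gap down to compound 1 at 2800 nM lies beyond the scatter. Compound 3 (`Clc1cccc(-c2ccc(-c3ccc(-c4nc5ccccc5[nH]4)cc3)cc2)c1`) has not yet been measured. It differs from compound 2 by having 3-chlorophenyl in place of 4-hydroxyphenyl on an aromatic carbon. For the measured compounds named here, no measured pair shows this change on its own, so any expectation rests on indirect evidence. Compound 1 also carries a 3-chlorophenyl group and gives 2800 nM, which points to a number for compound 3 in that region. In this assay a clear drop beyond the scatter is therefore expected, meaning stronger inhibition of growth than compound 2 shows. The estimated step is an 8.3-fold lower number from compound 2 to compound 3 (0.92 log units; beyond the scatter). The estimate for compound 3 is 4000 nM, with an expected range from 1500 nM to 11000 nM.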

Compound 3, concentration for 50% growth inhibition: 31100 nM
Beside the measured number, compound 3's estimate is 7.8-fold (0.89 log units) below it, outside the stated range (above it).
By their numbers in this assay, from the lowest: compound 1; then compounds 3 and 2 (each within the scatter of the next).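

In this assay the exchange of 4-hydroxyphenyl for 3-chlorophenyl, on an aromatic carbon para to a large group, comes to a 1.1-fold lower number from compound 2 to compound 3 (0.03 log units; within the scatter) and so does not separate the two groups in this assay. This holds even though the 4-hydroxyphenyl group counts a hydrogen-bond donor and a hydrogen-bond acceptor and the 3-chlorophenyl group counts neither. The step that does register lies at the other end of the molecule: with 3-chlorophenyl held fixed, hydrogen in place of methyl on an aromatic carbon gives an 11-fold higher number from compound 1 to compound 3 (1.05 log units; beyond the scatter) and thus ties the stronger inhibition of growth in compound 1 to that methyl group. Nothing at hand gives a reason for either step.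

As far as these compounds go, whether the methyl group would bring a similar step with 4-hydroxyphenyl at the chain's end remains open, so it is unknown if the two places act independently. Also open, from the compounds shown here alone, is whether an aminophenyl or a carboxyphenyl group at the end of the chain would stay as close to compound 2 and compound 3 as these two stay to each other.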